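This account rests on a few compounds, and the source may have more. Where it says the series, first, only, none or still open, it means among the compounds named here.

Measured in a functional assay (plasma) with Oryctolagus cuniculus as the target; on this read-out lower numbers stand for stronger inhibition and higher numbers for weaker inhibition:
- compound 1 `COC(=O)NC(CC(=O)N1CCC(n2c(C)nc3cnccc32)CC1)c1ccccc1`: 1300 nM
- compound 2 `Cc1nc2cnccc2n1CC1CCN(C(=O)CC(C)c2ccccc2)CC1`: 12 nM

Of these two, compound 2 has the lower number, and its gap to compound 1 lies beyond the scatter. Compound 3 `COc1ccccc1CCC(=O)N1CCC(Cn2c(C)nc3cnccc32)CC1` is not yet measured. It differs from compound 2 by 2-methoxybenzyl in place of 1-phenylethyl on a saturated chain carbon bound to a carbonyl carbon, with 2-methoxybenzyl in place of 1-phenylethyl on a saturated chain carbon bound to a carbonyl carbon. Within the data shown here, no measured pair shows this change, so the expectation is tentative. In this assay a moderate move to a higher number, meaning weaker inhibition, is expected, with an estimated step of a 3.3-fold higher number from compound 2 to compound 3 (0.52 log units; beyond the scatter). The estimate for compound 3 is 40 nM, with an expected range of 10 nM to 200 nM.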

Compound 3, half-maximal inhibitory concentration: 15 nM
Beside the measured number, compound 3's estimate is 2.7-fold (0.43 log units) above it; measured number inside the range.
By their numbers in this assay, from the lowest: compounds 2 and 3 (each within the scatter of the next); then compound 1.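

In this assay the step of 2-methoxybenzyl in place of 1-phenylethyl on a saturated chain carbon bound to a carbonyl carbon is a 1.3-fold higher number from compound 2 to compound 3 (0.10 log units; within the scatter) and shows no readable change in inhibition. This position therefore accepts a group with one hydrogen-bond acceptor and one more heavy atom without a shift beyond the scatter. Nothing on hand explains this result.

Still open, going by these compounds, is whether a carboxylic acid or a primary amine at this position would hold the number in this assay as well. A longer chain carrying the same aromatic ring also remains an open case.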